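A few compounds are considered here, and "the series" means these few. Any claim that something is new, unique, unknown or untested is made for them only; others in the source may bear on it.

Working notes on the series, read in a functional assay on SW-620 cells (Homo sapiens) for inhibition, read by MTT assay, with a stated time of 4 days; a lower number here means a stronger inhibitor, a higher number a weaker inhibitor. Compound 1 (`COc1cc(NC(C)CCCNC(=O)NNC(=O)NCCCCCO)c2ncccc2c1`) gives > 100000 nM, which is a limit and not a number. Compound 3 (`COc1cc(NC(C)CCCNC(=O)NNC(=O)NCCCC(C)Nc2cc(OC)cc3cccnc23)c2ncccc2c1`) gives > 100000 nM, also a limit. Compound 1 therefore stands at the limit of > 100000 nM in this assay, at which 2 of the 3 values shown sit. Among the compounds with values here, compound 2 (`CCOC(=O)N(C)C(c1ccccc1)c1ccccc1`) gives 27000 nM, the only true number so far.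

Compound 4 (`COc1cc(NC(C)CCCNC(=O)NNC(=O)N(CCO)CCO)c2ncccc2c1`) keeps the rest of compound 1 and carries bis(2-hydroxyethyl)amino in place of (5-hydroxypentyl)amino on a carbonyl carbon. Within the data shown here, no step between measured compounds is available to size this change.

In this assay no step beyond the scatter is expected for compound 4, given that compound 1 is a limit at > 100000 nM. The expected size of the change is a step that the limit leaves unreadable from compound 1 to compound 4, and no direction is favoured. Another report of a limit is the most likely outcome for this compound. As a number, compound 4 is estimated at 120000 nM, with an expected range from 50000 nM to 300000 nM.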

Compound 4, half-maximal inhibitory concentration: > 100000 nM
Compound 4: only a limit was reported; the forecaster's own chance of this, stated with the estimate: 85%; the middle value lies beyond the limit too.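

In this assay compound 4 gives > 100000 nM as a limit and not a number. Compound 1 also carries only a limit, so no step can be read from compound 1 to compound 4. The compounds shown leave open whether bis(2-hydroxyethyl)amino in place of (5-hydroxypentyl)amino on a carbonyl carbon changes inhibition at all: the limit of > 100000 nM in this assay, at which 3 of the 4 values shown sit.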